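The source may report more compounds than this note shows. Statements on the series, on what has been measured and on what is new or still open speak of the compounds shown alone.

Measured compounds:
- compound 1, `Cc1ccccc1-n1cc(-c2ccc(NS(=O)(=O)c3c[nH]c(=O)[nH]c3=O)cc2)nn1`: 7310 nM
- compound 2, `O=c1[nH]cc(S(=O)(=O)Nc2ccc(-c3cn(-c4ccccc4Cl)nn3)cc2)c(=O)[nH]1`: 4270 nM

In a functional assay on OVCAR-3 cells (Homo sapiens) for antiproliferative activity, read by MTT assay, with a stated time of 24 h (on this read-out higher numbers stand for weaker inhibition and lower numbers for stronger inhibition), compound 1 gives 7310 nM and compound 2 gives 4270 nM; the single step between them, a 1.7-fold lower number from compound 1 to compound 2 (0.23 log units; within the scatter), does not separate the two, so compound 2 stands at neither end of anything on the numbers shown.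

Compound 3, `O=c1[nH]cc(S(=O)(=O)Nc2ccc(-c3cn(-c4cccc(Cl)c4)nn3)cc2)c(=O)[nH]1`, is not yet measured in this assay. It differs from compound 2 in one place: 3-chlorophenyl in place of 2-chlorophenyl on an aromatic nitrogen. Among the measured compounds shown here, no measured step moves a chloro group from one ring position to another; the one step seen, a 1.7-fold lower number from compound 1 to compound 2 (0.23 log units; within the scatter), swaps methyl for chloro and stays within the scatter. Nothing here points to a change beyond the scatter in either direction, so compound 3 is expected to sit close to compound 2 in this assay, with a 1.0-fold higher number from compound 2 to compound 3 (0.00 log units; within the scatter) as the estimated step. For compound 3 the estimate is 4300 nM, within 1500 nM to 12000 nM.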

Compound 3, half-maximal inhibitory concentration: 2750 nM
Compound 3: middle estimate off by 1.6-fold (0.19 log units), on the high side, and the stated range covers the measured number.
By their numbers in this assay, from the lowest: compounds 3, 2 and 1 (each within the scatter of the next, the first and the last beyond it).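

In this assay, moving from 2-chlorophenyl to 3-chlorophenyl on the aromatic nitrogen gives a 1.6-fold lower number from compound 2 to compound 3 (0.19 log units; within the scatter), so the two chlorophenyl groups are not separated on these numbers. Against the 2-methylphenyl group of compound 1, the 3-chlorophenyl group gives a 2.7-fold lower number from compound 1 to compound 3 (0.42 log units; beyond the scatter), the only step in the series so far that lies beyond the scatter, though still a modest one. This step changes both the group and its ring position, so the compounds shown do not assign it to either, and no measurement at hand bears on the reason for it.

From the compounds shown here alone, it remains open whether methyl in the ring position held by chloro in compound 3 would give a number like that of compound 3, which would separate the two changes. Also open, going by these compounds, is whether an amine or a carboxylic acid in place of the chloro on this ring would move the number beyond the scatter in either direction.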